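Chloro to bromo on an imide series at the glutamate receptor

This account rests on a few compounds, and the source may have more. Where it says the series, first, only, none or still open, it means among the compounds named here.

Measured so far, in an assay on CHO cells for positive allosteric modulation of metabotropic glutamate receptor 5 (Homo sapiens), read by FLIPR; on this read-out higher numbers stand for an effect only at larger amounts of compound and lower numbers for an effect already at smaller amounts:
Compound 1, `COc1ccc2c(c1OC)C(=O)N(Cc1cc(Br)ccc1NC(=O)c1ccccn1)C2=O`, gives > 100000 nM, which is a limit of the assay and not a number.
Compound 2, `CCOc1cccc2c1C(=O)N(Cc1cc(Cl)ccc1NC(=O)c1ccccn1)C2=O`, gives 280 nM.
Compound 3, `COc1ccc2c(c1OC)C(=O)N(Cc1cc(Cl)ccc1NC(=O)c1ccccn1)C2=O`, gives > 100000 nM, again a limit and not a number.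

Compound 2 is the only one of the three with a number; the other two sit at a limit, as the limit of > 100000 nM in this assay, at which 2 of the 3 values shown sit, records. Compound 2 and compound 3 carry different cores, and the difference between the two cores is not broken down here.

One change appears twice among these compounds. From compound 3 to compound 1 it is bromo in place of chloro on an aromatic carbon, and the step that the two limits leave unreadable from compound 3 to compound 1, since both ends are limits. From compound 2 to the unmeasured compound 4, `CCOc1cccc2c1C(=O)N(Cc1cc(Br)ccc1NC(=O)c1ccccn1)C2=O`, the same change is made: bromo in place of chloro on an aromatic carbon.

Because the step that the two limits leave unreadable from compound 3 to compound 1 gives no readable size, the expectation for compound 4 rests on compound 2 and its value 280 nM alone, with a step estimated as a 1.1-fold higher number from compound 2 to compound 4 (0.03 log units; within the scatter). Compound 4 is thus expected near 300 nM, between 100 nM and 900 nM.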

Compound 4, half-maximal effective concentration: 720 nM
Estimate against measurement, compound 4: 2.4-fold (0.38 log units) below; the range from low to high includes it.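

Putting bromo in place of chloro on the core shared by the later pair gives, in this assay, a 2.6-fold higher number from compound 2 to compound 4 (0.41 log units; beyond the scatter), so on this core the change is modest and compound 4 still has a measurable effect. The same change on the other core cannot be read, which leaves no second size to set against this one, since compound 3 and compound 1 both stand at a limit and not at a number: the limit of > 100000 nM in this assay, at which 2 of the 4 values shown sit.
One readable step on one core therefore gives no rule for the series, and it does not show that the change would have a similar size on any other core.

Still open, from the compounds shown here alone, is how fluoro, methyl or a nitrile would compare with chloro and bromo at the same place, para to the ((pyridin-2-yl)carbonyl)amino group, on the core of compound 2. Also open, going by these compounds, is which feature of the core of compound 2 sets it apart from the core of compound 3, as these two differ in more than one place.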